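Swapping a tert-butyl for an acetylsulfamoyl on a kinase binder

The source may hold more compounds than are shown below. What is called first, only, known or untested is meant among the compounds shown, and "the series" means these compounds.

Measured compounds:
- compound 1, `CCCS(=O)(=O)Nc1ccc(F)c(C(=O)c2n[nH]c3ncc(-c4ccc(N(C)C)cc4)cc23)c1F`: 2.5%
- compound 2, `CCCS(=O)(=O)Nc1ccc(F)c(C(=O)c2n[nH]c3ncc(-c4cc(Cl)cc(Cl)c4)cc23)c1F`: 73%
- compound 3, `CCCS(=O)(=O)Nc1ccc(F)c(C(=O)c2n[nH]c3ncc(-c4ccc(C(C)(C)C)cc4)cc23)c1F`: 46%

All three share one core and differ only in the aryl group attached to it. In an assay for binding affinity to dual specificity mitogen-activated protein kinase kinase 4 (Homo sapiens), read by KINOMEscan, tested at 100 nM (on this read-out lower numbers stand for a stronger effect and higher numbers for a weaker effect at the one concentration tested), compound 1 gives 2.5%, compound 2 gives 73% and compound 3 gives 46%. Compound 3 thus stands second highest of the three numbers: a number 27 percentage points lower from compound 2 to compound 3 (beyond the scatter), while a number 43.5 percentage points higher from compound 1 to compound 3 (beyond the scatter).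

Compound 4, `CCCS(=O)(=O)Nc1ccc(F)c(C(=O)c2n[nH]c3ncc(-c4ccc(S(=O)(=O)NC(C)=O)cc4)cc23)c1F`, is not yet measured. It differs from compound 3 in one place: acetylsulfamoyl in place of tert-butyl on an aromatic carbon.

Among the measured compounds shown here, no measured step involves an acetylsulfamoyl, so none bears directly on this change. The closest is the exchange at the same position, where a number 43.5 percentage points higher from compound 1 to compound 3 (beyond the scatter); that step shows the group at this place can move the read-out by a large amount, but gives no sign for the direction here. A large step in either direction is therefore possible, and the expectation stays near the middle of the observed numbers.

Compound 4 is estimated at 50%, within 10% to 90%, which means an expected step of a number 4 percentage points higher from compound 3 to compound 4 (within the scatter).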

Compound 4, a percentage reported as activity, at one concentration (the size of the read-out at that concentration, not a potency): 0.35%
Compound 4: the middle estimate sits 49.7 percentage points above what was measured; measured number outside the range, below it.
By their numbers in this assay, from the lowest: compounds 4 and 1 (each within the scatter of the next); then compound 3; then compound 2.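

In this assay, putting acetylsulfamoyl at this place on the aryl ring brings a large change (a number 45.7 percentage points lower from compound 3 to compound 4 (beyond the scatter)), so a low number here does not depend on dimethylamino alone. Against dimethylamino the result is level within the scatter (a number 2.2 percentage points lower from compound 1 to compound 4 (within the scatter)), so two quite different groups reach the same low range, while tert-butyl, which has no hydrogen-bond donors or acceptors, stays well above it. Nothing available explains why these groups differ.

Which part of acetylsulfamoyl matters stays open: a plain sulfamoyl without the acetyl, a carboxylic acid or a simple amine at this place could separate the contributions of its parts. A single-concentration read-out also leaves open whether compound 1 and compound 4 differ in true potency.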